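The source may hold more compounds than are shown below. What is called first, only, known or untested is meant among the compounds shown, and "the series" means these compounds.

Measured so far in a functional assay on NFS-60 cells (Mus musculus) for inhibition, read by MTT assay, with a stated time of 72 h; on this read-out lower numbers stand for stronger inhibition and higher numbers for weaker inhibition: compound 1 `O=C(OC1(C(=O)Nc2ccc([N+](=O)[O-])cc2)CCCCC1)c1ccc(C(F)(F)F)cc1` gives 26 nM; compound 2 `O=C(/C=C/c1ccccc1)OC1(C(=O)Nc2ccc([N+](=O)[O-])cc2)CCCCC1` gives 50.5 nM; compound 3 `CC(=O)OC1(C(=O)Nc2ccc([N+](=O)[O-])cc2)CCCCC1` gives 517 nM.

Compound 3 thus stands highest of the three numbers in this assay, with steps to both other compounds that lie beyond the scatter: a 20-fold higher number from compound 1 to compound 3 (1.30 log units; beyond the scatter) and a 10-fold higher number from compound 2 to compound 3 (1.01 log units; beyond the scatter). Compound 4 `CCC(=O)OC1(C(=O)Nc2ccc([N+](=O)[O-])cc2)CCCCC1` differs from compound 3 by methyl in place of hydrogen on a saturated chain carbon bound to a carbonyl carbon, that is acetyl to propanoyl. Within the data shown here, the two steps that bear on it, a 20-fold higher number from compound 1 to compound 3 (1.30 log units; beyond the scatter) and a 10-fold higher number from compound 2 to compound 3 (1.01 log units; beyond the scatter), both swapped a large group on that carbonyl carbon for methyl and gave large higher numbers; no measured step tests a change as small as methyl to ethyl. Compound 4 is therefore expected to show a 1.3-fold lower number from compound 3 to compound 4 (0.11 log units; within the scatter), a step not clearly beyond the scatter. Compound 4 is estimated at 400 nM, between 150 nM and 1100 nM.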

Compound 4, half-maximal inhibitory concentration: 6.4 nM
Compound 4: the middle estimate sits 63-fold (1.80 log units) above what was measured, outside the stated range (below it).
By their numbers in this assay, from the lowest: compound 4; then compounds 1 and 2 (each within the scatter of the next); then compound 3.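

In this assay one added methyl on a saturated chain carbon bound to a carbonyl carbon, acetyl to propanoyl, carries a far larger step than the earlier swaps suggested (an 81-fold lower number from compound 3 to compound 4 (1.91 log units; beyond the scatter)). Ethyl on that carbonyl carbon also gives a lower number than either 2-phenylethenyl (a 7.9-fold lower number from compound 2 to compound 4 (0.90 log units; beyond the scatter)) or 4-(trifluoromethyl)phenyl (a 4.1-fold lower number from compound 1 to compound 4 (0.61 log units; beyond the scatter)), so the earlier order, with methyl highest, does not carry over to ethyl. No measured evidence here accounts for this step.

The compounds shown leave open whether a longer chain such as butanoyl, or a branched isobutanoyl group, would keep the number of compound 4 or lose it.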